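Notes on the series: from compound 1 to compound 4

The compounds below may be only part of what the source reports. "The series", "measured", "known", "first", "only" and "open" are said of these compounds alone.

Values from a functional assay, with a stated time of 30 min (a higher number here means that more compound is needed for the effect, a lower number that less compound is needed), are as follows
- compound 1 `CC/C(C)=N\Nc1nc(-c2cccc([N+](=O)[O-])c2)cs1` gives 580000 nM
- compound 2 `CCC(CC)=NNc1nc(-c2cccc([N+](=O)[O-])c2)cs1` gives 460000 nM
- compound 3 `C=CCC/C(C)=N\Nc1nc(-c2cccc([N+](=O)[O-])c2)cs1` gives 460000 nM

Compound 1 is not separated from the other two compounds. Both a 1.3-fold lower number from compound 1 to compound 2 (0.10 log units; within the scatter) and a 1.3-fold lower number from compound 1 to compound 3 (0.10 log units; within the scatter) stay within the scatter.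

Compound 4 `CCC/C(CC)=N\Nc1nc(-c2cccc([N+](=O)[O-])c2)cs1` remains to be measured. The change from compound 1 is a group of 7 heavy atoms (6 carbon, 1 nitrogen; no ring) in place of a group of 5 heavy atoms (4 carbon, 1 nitrogen; no ring), on a nitrogen on an aromatic ring and it falls in the same group that varies across compound 2 and compound 3.

The further measured step no change at the digits printed from compound 2 to compound 3 (within the scatter) also stays within the scatter. Going by the values given here, the group entering compound 4 matches in heavy-atom count the one on compound 3, which gives 460000 nM and is the closest guide. None of these steps leaves the scatter, so no shift beyond it is expected in this assay in either direction. The expected step is a 1.3-fold lower number from compound 1 to compound 4 (0.11 log units; within the scatter) and it lies within the scatter. For compound 4 the estimate is 450000 nM with 250000 nM to 800000 nM as its expected range.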

Compound 4, half-maximal effective concentration: 530000 nM
Compound 4: the middle estimate sits 1.2-fold (0.07 log units) below what was measured, within the range that was stated.
By their numbers in this assay, from the lowest: compounds 2, 3, 4 and 1 (each within the scatter of the next).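

In this assay, a group of 7 heavy atoms (6 carbon, 1 nitrogen; no ring) in place of a group of 5 heavy atoms (4 carbon, 1 nitrogen; no ring), on a nitrogen on an aromatic ring, gives a 1.1-fold lower number from compound 1 to compound 4 (0.04 log units; within the scatter) and stays within the scatter. Two different groups of equal heavy-atom count at this place show a 1.2-fold higher number from compound 3 to compound 4 (0.06 log units; within the scatter) as their step, and methyl in place of hydrogen on a saturated chain carbon gives a 1.2-fold higher number from compound 2 to compound 4 (0.06 log units; within the scatter) with no separation either. All four compounds therefore remain undivided at this position, and nothing in hand bears on why this is so.

The compounds shown carry only open-chain groups at this place. As far as these compounds go, whether a cyclohexyl ring or a chain bearing an amine there would leave the scatter remains open.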